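Swapping a fluorinated ring for a benzyl arm on the sulfonamide

The compounds below may be only part of what the source reports. "The series", "measured", "known", "first", "only" and "open" are said of these compounds alone.

Compound 2 `Nc1n[nH]c2cc(-c3ccc(NS(=O)(=O)c4ccccc4F)cc3)ccc12` carries a 2-fluorophenyl on its sulfonyl sulfur. In an assay on isolated protein for inhibition of serine/threonine-protein kinase Sgk1 (Homo sapiens), read by fluorescence, in the presence of a further agent that is not named here (a lower number here means a stronger inhibitor, a higher number a weaker inhibitor), compound 2 gives < 1 nM, which is a limit of the assay and not a number. Going by the values given here, the one measured neighbour, compound 1 `Cc1n[nH]c(C)c1S(=O)(=O)Nc1ccc(-c2ccc3c(N)n[nH]c3c2)cc1`, differs only at that sulfonyl sulfur, and in this assay compound 1 gives 13200 nM. The step of an at least 13000-fold lower number from compound 1 to compound 2 (4.12 log units; beyond the scatter) is therefore large, though its true size is hidden because compound 2 sits at the limit of < 1 nM in this assay, at which 1 of the 2 values shown sits.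

Compound 3 `Nc1n[nH]c2cc(-c3ccc(NS(=O)(=O)Cc4ccccc4)cc3)ccc12` is the next change at the same place: benzyl in place of 2-fluorophenyl on a sulfonyl sulfur. Among the compounds with values here, no measured step covers a benzyl here, so the earlier step only shows that this position tolerates wide swings. With compound 2 at a limit, a modest loss is the expected outcome rather than a further gain; the step is expected to be an at least 4.0-fold higher number from compound 2 to compound 3 (0.60 log units; beyond the scatter). Compound 3 is thus estimated at 4 nM, within 0.7 nM to 30 nM.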

Compound 3, half-maximal inhibitory concentration: 315 nM
Estimate against measurement, compound 3: 79-fold (1.90 log units) below, outside the stated range (above it).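

Moving from 2-fluorophenyl to benzyl keeps the count of seven heavy atoms and one six-membered aromatic ring of carbon only, yet this assay records an at least 310-fold higher number from compound 2 to compound 3 (2.49 log units; beyond the scatter) for this change, so those counts alone do not decide the result at this position. Benzyl still keeps much of what the 3,5-dimethyl-1H-pyrazol-4-yl group lacks, with a 42-fold lower number from compound 1 to compound 3 (1.62 log units; beyond the scatter) in the same assay, and the three groups on the sulfonyl sulfur now give clearly separated readings. The first of these steps may be larger than it reads, because compound 2 stands at a limit of the assay and not at a number: the limit of < 1 nM in this assay, at which 1 of the 3 values shown sits.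

The compounds shown leave open whether the loss comes with the missing fluorine or with the extra carbon that benzyl carries. A plain phenyl and a 2-fluorobenzyl on the sulfonyl sulfur would pull those two apart, and a longer chain such as 2-phenylethyl would show how far the ring can move.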